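Notes toward compound 4: dichlorophenyl replacing cyanophenyl

The source may report more compounds than this note shows. Statements on the series, on what has been measured and on what is new or still open speak of the compounds shown alone.

Among the three measured compounds, compound 3 `CC1=C(C(=O)OCC2CCN(C(=O)OC(C)(C)C)CC2)C(c2cccc(C#N)c2)C2=C(CC(C)(C)CC2=O)N1` gives 220 nM in an assay on HEK293 cells for inhibition of neurogenic locus notch homolog protein 1 (Homo sapiens), read by a luciferase reporter and resazurin assay, with a stated time of 16 h (on this read-out higher numbers stand for weaker inhibition and lower numbers for stronger inhibition), the smallest of the numbers, though compound 2 `CC1=C(C(=O)OCC2CCN(C(=O)OC(C)(C)C)CC2)C(c2cccc(Br)c2)C2=C(CC(C)(C)CC2=O)N1` with 360 nM is within the scatter of it, the step being a 1.6-fold lower number from compound 2 to compound 3 (0.21 log units; within the scatter). Compound 1 `CC1=C(C(=O)OC2CCCCC2)C(c2cccc(C(F)(F)F)c2)C2=C(CC(C)(C)CC2=O)N1` gives 14700 nM; it differs from compound 3 in two places, so its far higher number cannot be assigned to the aryl group alone.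

Compound 4 `CC1=C(C(=O)OCC2CCN(C(=O)OC(C)(C)C)CC2)C(c2cc(Cl)cc(Cl)c2)C2=C(CC(C)(C)CC2=O)N1` differs from compound 3 by 3,5-dichlorophenyl in place of 3-cyanophenyl on a saturated ring carbon. Going by the values given here, the only measured step that bears on a change of the aryl substituent is a 1.6-fold lower number from compound 2 to compound 3 (0.21 log units; within the scatter), which lies within the scatter; no measured pair shows a halogen in place of the nitrile, nor a second substituent on the ring. With that single, flat precedent, the expected step in this assay from compound 3 to compound 4 is a 1.4-fold higher number from compound 3 to compound 4 (0.13 log units; within the scatter), that is none beyond the scatter. Compound 4 is therefore expected to give about 300 nM in this assay, with a range from 100 nM to 900 nM.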

Compound 4, half-maximal inhibitory concentration: 640 nM
Compound 4: middle estimate off by 2.1-fold (0.33 log units), on the low side, within the range that was stated.
By their numbers in this assay, from the lowest: compounds 3, 2 and 4 (each within the scatter of the next, the first and the last beyond it); then compound 1.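

In this assay, this saturated ring carbon shows its first aryl change beyond the scatter, with 3,5-dichlorophenyl in place of 3-cyanophenyl (a 2.9-fold higher number from compound 3 to compound 4 (0.46 log units; beyond the scatter)). Against 3-bromophenyl, the same ring gives a step within the scatter (a 1.8-fold higher number from compound 2 to compound 4 (0.25 log units; within the scatter)), so the series does not separate these two aryl groups, and a second halogen on the ring is accepted with the number staying in the range of compound 2. No evidence bears on the difference between the nitrile ring and the dichloro ring.

A 3-chlorophenyl ring would separate the loss of the nitrile from the gain of a second chlorine. On these data alone, whether an amine or a carboxylic acid on the aryl ring is accepted at this position also remains open.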